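The source may hold more compounds than are shown below. What is called first, only, known or untested is meant among the compounds shown, and "the series" means these compounds.

Compounds measured so far in an assay on HL-60 cells for inhibition of glutathione S-transferase P (Homo sapiens), read by spectrophotometry, tested at 20 uM; on this read-out lower numbers stand for less inhibition and higher numbers for more inhibition at the one concentration tested (going by the name of the read-out):

compound 1 `COc1ccc(OC)c(/C=C2\CN(CC(=O)O)c3c(C)cccc3C2=O)c1`: 5.44%
compound 2 `COc1cc(/C=C2\CN(CC(=O)O)c3c(C)cccc3C2=O)cc(OC)c1`: 32.3%
compound 3 `COc1ccccc1/C=C1\CN(CC(=O)O)c2c(C)cccc2C1=O`: 4.72%

Among these three, compound 2 gives the highest number in this assay, and the gap to compound 1 and to compound 3 is beyond the usual scatter in each case. Compound 1 and compound 3 lie within the scatter of each other, so their numbers cannot be put in order. Among the measured compounds shown here, the one step measured between compounds that differ in a single place is a number 0.7 percentage points lower from compound 1 to compound 3 (within the scatter): removing a methoxy group from the ring made no difference that can be told from noise.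

Compound 4 `COc1cc(/C=C2\CN(CC(=O)O)c3c(C)cccc3C2=O)cc(OC)c1OC` is not yet measured. It differs from compound 2 by methoxy in place of hydrogen on an aromatic carbon, the new group entering ortho to two methoxy groups and para to a large group. The measured step concerns a methoxy at a different place, so it bears only loosely on this change, and it was small. The expectation is therefore a step of a number 2.3 percentage points lower from compound 2 to compound 4 (within the scatter), which is none beyond the scatter. Compound 4 is expected to give about 30%, with a likely range from 12% to 48%.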

Compound 4, a percentage reported as inhibition, at one concentration (the size of the read-out at that concentration, not a potency): 0.85%
Beside the measured number, compound 4's estimate is 29.2 percentage points above it; measured number outside the range, below it.
By their numbers in this assay, from the lowest: compounds 4, 3 and 1 (each within the scatter of the next); then compound 2.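

On the ring of compound 2, a methoxy group entering ortho to two methoxy groups and para to a large group is far from a neutral change, with a number 31.5 percentage points lower from compound 2 to compound 4 (beyond the scatter). Compound 2 now stands alone at the top, while compounds 4, 3 and 1 each lie within the scatter of the next. The earlier small step therefore cannot be carried over to this position, and the same exchange of hydrogen and methoxy can matter on one substitution pattern and not on another: the same change on two cores in this assay, a number 0.7 percentage points lower (within the scatter) from compound 1 to compound 3 and a number 31.5 percentage points higher (beyond the scatter) from compound 4 to compound 2, 32.2 percentage points apart, beyond the scatter of two such steps

As far as these compounds go, it remains open whether a hydroxyl group, a fluorine atom or a methyl group at this position would give the same drop, or whether it is specific to methoxy. These percentages also come from one concentration, so they leave the potency of compound 2 unknown.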